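A few compounds are considered here, and "the series" means these few. Any claim that something is new, unique, unknown or untested is made for them only; others in the source may bear on it.

Measured compounds:
- compound 1, `COC(=O)c1cnc(C(=O)CCc2ccc(COc3ccccc3)cc2)o1`, 1.6 nM
- compound 2, `COC(=O)c1cnc(C(=O)CCc2ccc(Oc3ccccc3)cc2)o1`, 1.7 nM
- compound 3, `COC(=O)c1cnc(C(=O)CCc2ccc(-c3ccccc3)cc2)o1`, 1.5 nM

In an assay for inhibition of Fatty-acid amide hydrolase 1 (Rattus norvegicus) (a lower number here means a stronger inhibitor, a higher number a weaker inhibitor), compound 2 holds the highest of the three numbers, but the steps from it are small: a 1.1-fold higher number from compound 1 to compound 2 (0.03 log units; within the scatter) and a 1.1-fold lower number from compound 2 to compound 3 (0.05 log units; within the scatter) both sit within the scatter, as does a 1.1-fold lower number from compound 1 to compound 3 (0.03 log units; within the scatter). The three measured compounds therefore read as equivalent, and what they vary is the group on the distal phenyl ring, not the shared core.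

Compound 4, `O=C(CCc1ccc(Oc2ccccc2)cc1)c1ncc(I)o1`, is different in kind. It keeps the phenoxy tail of compound 2 and changes the core: iodo in place of methoxycarbonyl on an aromatic carbon. None of the three measured steps touches this position; each concerns the far end of the molecule and each was flat. Among the measured compounds shown here, they say nothing about how the number responds when the methoxycarbonyl is exchanged for iodo, so no measured step supports a firm direction. The expectation for compound 4 in this assay is accordingly uncertain, and the step of a 4.7-fold higher number from compound 2 to compound 4 (0.67 log units; beyond the scatter) is expected only loosely, with a wide range. Compound 4 is estimated at 8 nM, between 1.5 nM and 60 nM.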

Compound 4, inhibition constant: 10 nM
Compound 4: the middle estimate sits 1.3-fold (0.10 log units) below what was measured, and the stated range covers the measured number.
By their numbers in this assay, from the lowest: compounds 3, 1 and 2 (each within the scatter of the next); then compound 4.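

Where the three changes at the far end of the molecule left the number flat, the first change shown on the shared core moves it: iodo in place of methoxycarbonyl, next to the ring oxygen, gives in this assay a 5.9-fold higher number from compound 2 to compound 4 (0.77 log units; beyond the scatter) and so marks this position as one that responds. The step is modest, and compound 4 keeps a low number of 10 nM with one heavy atom at this position instead of four and without the two hydrogen-bond acceptors of methoxycarbonyl. Nothing available explains why the number rises with this exchange.

One replacement cannot separate the loss of methoxycarbonyl from the arrival of iodo. Going by these compounds, whether a carboxylic acid, a primary amide or a chlorine atom here would behave likewise remains open, as does whether iodo would give a similar step with the tails of compound 1 and compound 3.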